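Swapping cycloheptyl for 4-chlorophenyl on the amide nitrogen

The compounds below may be only part of what the source reports. "The series", "measured", "known", "first", "only" and "open" are said of these compounds alone.

Compound 1, `Cc1nc(C(NC(=O)C(=O)Nc2ccc(Cl)cc2)C2CCCN2)sc1CCO`: 4900 nM
Compound 2, `Cc1nc(C(NC(=O)C(=O)NC2CCCCCC2)C2CCCCN2)sc1CCO`: > 88000 nM

Of the compounds shown here, two have been tested in an ADME assay on TZM-b1 cells (Homo sapiens) for cytotoxicity, read by XTT assay, with a stated time of 3 days; a higher number here means that more compound is tolerated, a lower number that less compound is tolerated. Compound 1, `Cc1nc(C(NC(=O)C(=O)Nc2ccc(Cl)cc2)C2CCCN2)sc1CCO`, gives 4900 nM. Compound 2, `Cc1nc(C(NC(=O)C(=O)NC2CCCCCC2)C2CCCCN2)sc1CCO`, gives > 88000 nM, which is a limit of the assay rather than a number. As far as these compounds go, compound 2 thus sits at the limit of > 88000 nM in this assay, at which 1 of the 2 values shown sits, and how far beyond it the true value lies is unknown.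

Compound 3, `Cc1nc(C(NC(=O)C(=O)Nc2ccc(Cl)cc2)C2CCCCN2)sc1CCO`, has not yet been measured. It differs from compound 2 in one place: 4-chlorophenyl in place of cycloheptyl on an amide-type nitrogen, that is, cycloheptylamino becomes (4-chlorophenyl)amino. Within the data shown here, no step between two measured compounds covers this change alone; compound 1 carries the same 4-chlorophenyl group but differs from compound 3 elsewhere too, so it serves only as a hint. Because compound 1 gives 4900 nM with that group in place, compound 3 is expected to tolerate less compound than compound 2. The expected step is downward and beyond the scatter: an at least 11-fold lower number from compound 2 to compound 3 (1.04 log units; beyond the scatter). For compound 3 the estimate is 8000 nM, with a range from 2500 nM to 40000 nM.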

Compound 3, half-maximal cytotoxic concentration: 32800 nM
For compound 3 the middle estimate is 4.1-fold (0.61 log units) below the measured one; low and high end bracket the measured number.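

In this assay, the change on the amide-type nitrogen now has its first direct reading: with the rest of the structure held the same, 4-chlorophenyl in place of cycloheptyl gives an at least 2.6-fold lower number from compound 2 to compound 3 (0.42 log units; beyond the scatter), so less compound is tolerated with the aromatic ring in that place. Compound 2 stands at a limit of the assay and not at a number, so this step fixes only a minimum size, and its full size remains unknown: the limit of > 88000 nM in this assay, at which 1 of the 3 values shown sits.

The result also shows that 4-chlorophenyl alone does not set the number, since with that group kept in both compounds, piperidin-2-yl in place of pyrrolidin-2-yl gives a 6.7-fold higher number from compound 1 to compound 3 (0.83 log units; beyond the scatter).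

As far as these compounds go, whether the lower tolerated concentration goes with the aromatic ring itself or with its chlorine stays open, and a plain phenyl on the same nitrogen would help separate the two. Also open, from the compounds shown here alone, is whether the step between the two saturated rings would keep its direction and size with cycloheptyl on the nitrogen, or how a morpholine ring would read in their place.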